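Working notes on the shared core: step to compound 4

A few compounds are considered here, and "the series" means these few. Any claim that something is new, unique, unknown or untested is made for them only; others in the source may bear on it.

Measured so far:
Compound 1 `COc1ccc(-c2ccc3c(O)cccc3c2)cc1` gives 20% in an assay for binding affinity to 17-beta-hydroxysteroid dehydrogenase type 2 (Homo sapiens), with a stated time of 20 min, tested at 1 uM; a lower number here means less inhibition, a higher number more inhibition at the concentration tested (going by the name of the read-out).
Compound 2 `O=[N+]([O-])c1ccc(-c2ccc3c(O)cccc3c2)cc1` gives 13% in this assay.
Compound 3 `O=C(O)c1ccc(-c2ccc3c(O)cccc3c2)cc1` gives 16% in this assay.

Compound 3 stands second highest of the three numbers in this assay. Its nearest neighbour is compound 2, with a number 3 percentage points higher from compound 2 to compound 3 (within the scatter); the furthest is compound 1, with a number 4 percentage points lower from compound 1 to compound 3 (within the scatter). Both steps lie within the scatter, so no order among the three can be read from them.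

Compound 4 `CNS(=O)(=O)c1ccc(-c2ccc3c(O)cccc3c2)cc1` is not yet measured. It differs from compound 3 by methylsulfamoyl in place of carboxy on an aromatic carbon.

Every measured step in this series is an exchange of the group at that same aromatic carbon: a number 7 percentage points lower from compound 1 to compound 2 (within the scatter), a number 4 percentage points lower from compound 1 to compound 3 (within the scatter) and a number 3 percentage points higher from compound 2 to compound 3 (within the scatter). None of them reached beyond the scatter. Nothing here marks out methylsulfamoyl as different, so for compound 4 a step within the scatter is expected, a number 1 percentage points higher from compound 3 to compound 4 (within the scatter). For compound 4 the estimate in this assay is 17%, with a range from 5% to 30%.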

Compound 4, a percentage reported as inhibition, at one concentration (the size of the read-out at that concentration, not a potency): 57%
Compound 4: middle estimate off by 40 percentage points, on the low side; the whole stated range lies below it.
By their numbers in this assay, from the lowest: compounds 2, 3 and 1 (each within the scatter of the next); then compound 4.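

At this aromatic carbon, para to a large group, methoxy, nitro and carboxy could not be told apart, so the position looked indifferent to the exchange; methylsulfamoyl shows that it is not. In this assay it stands clear of all three: in place of carboxy (a number 41 percentage points higher from compound 3 to compound 4 (beyond the scatter)), in place of nitro (a number 44 percentage points higher from compound 2 to compound 4 (beyond the scatter)) and in place of methoxy (a number 37 percentage points higher from compound 1 to compound 4 (beyond the scatter)). No data here bear on the reason for this gain.

Still open, from the compounds shown here alone, is which part of methylsulfamoyl carries the gain. Unsubstituted sulfamoyl, dimethylsulfamoyl and methylsulfonyl at this carbon would separate the parts.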